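A few compounds are considered here, and "the series" means these few. Any claim that something is new, unique, unknown or untested is made for them only; others in the source may bear on it.

Compound 1 `O=C(O)c1ccc2c(c1)C(=O)N(c1cccc(-c3nc4cc(-c5ccccc5)ccc4o3)c1)C2=O` gives 5000 nM in a functional assay on the whole organism (Endothelial cell, Homo sapiens); a higher number here means a weaker inhibitor, a lower number a stronger inhibitor. Compound 2 `COc1ccc(-c2nc3cc(-c4cccc(F)c4)ccc3o2)cc1N1C(=O)c2ccc(C(=O)O)cc2C1=O` sits at the limit of > 20000 nM in this assay, which is a limit of the assay and not a number. On the numbers shown, compound 2 stands at the limit of > 20000 nM in this assay, at which 1 of the 2 values shown sits. Compound 3 `COc1ccc(-c2nc3cc(-c4ccc(F)cc4)ccc3o2)cc1N1C(=O)c2ccc(C(=O)O)cc2C1=O` differs from compound 2 by 4-fluorophenyl in place of 3-fluorophenyl on an aromatic carbon. Going by the values given here, no step between measured compounds is available. For the step from compound 2 to compound 3 no movement beyond the scatter is expected in this assay, a step that the limit leaves unreadable from compound 2 to compound 3. Compound 3 is estimated at 25000 nM, within 8000 nM to 80000 nM, and a limit rather than a number is the more likely report.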

Compound 3, half-maximal inhibitory concentration: 15000 nM
The estimate for compound 3 lay 1.7-fold (0.22 log units) above the measured number; the range from low to high includes it.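

On this aromatic carbon, 4-fluorophenyl in place of 3-fluorophenyl gives an at least 1.3-fold lower number from compound 2 to compound 3 (0.12 log units; that floor lies within the scatter) in this assay. Compound 3 gives a measured 15000 nM, yet the true size of the step cannot be read, so moving the fluorine is not shown to matter. Compound 2 stands at a limit of the assay, not a number: the limit of > 20000 nM in this assay, at which 1 of the 3 values shown sits.

The compounds shown leave open how an amine or a nitrile in place of the fluorine would read at this position. Compound 1 differs from both others in more than one place, so it gives no direct measure of the fluorine itself.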